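This account rests on a few compounds, and the source may have more. Where it says the series, first, only, none or still open, it means among the compounds named here.

In a functional assay on MCF7 cells (Homo sapiens) for inhibition, read by MTT assay, with a stated time of 72 h (a lower number here means a stronger inhibitor, a higher number a weaker inhibitor), the three measured compounds stand as follows:

Compound 1, `Cc1cc(Nc2cc(-c3ccccc3)[nH]n2)n2ncnc2n1`, gives > 50000 nM, a limit of the assay.
Compound 2, `CCCSc1nc2nc(C)cc(Nc3cc(-c4ccccc4)[nH]n3)n2n1`, gives > 50000 nM, a limit of the assay.
Compound 3, `Cc1cc(Nc2cc(-c3ccccc3)[nH]n2)n2nc(SCC3CC3)nc2n1`, gives > 50000 nM, a limit of the assay.

Compound 3 thus sits at the limit of > 50000 nM in this assay, at which 3 of the 3 values shown sit, with no number of its own. The steps that touch the sulfanyl substituent, a step that the two limits leave unreadable from compound 1 to compound 3 and a step that the two limits leave unreadable from compound 2 to compound 3, are both unreadable, so they give no size in either direction. Compound 4, `COc1ccc(CSc2nc3nc(C)cc(Nc4cc(-c5ccccc5)[nH]n4)n3n2)cc1`, differs from compound 3 by 4-methoxyphenyl in place of cyclopropyl on a saturated chain carbon bound to a sulfur. With every neighbouring value a limit, the step is expected to be an at least 1.2-fold lower number from compound 3 to compound 4 (0.09 log units; that floor lies within the scatter), and compound 4 is estimated at 40000 nM, between 8000 nM and 200000 nM, most likely again as a limit.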

Compound 4, half-maximal inhibitory concentration: 4020 nM
For compound 4 the middle estimate is 10-fold (1.00 log units) above the measured one; measured number below the stated range.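

In this assay, the position on the saturated chain carbon bound to the sulfur gives its first readable effect: 4-methoxyphenyl in place of cyclopropyl is an at least 12-fold lower number from compound 3 to compound 4 (1.09 log units; beyond the scatter), and in place of ethyl it is an at least 12-fold lower number from compound 2 to compound 4 (1.09 log units; beyond the scatter). Measured against the unsubstituted core, the whole (4-methoxybenzyl)sulfanyl group is an at least 12-fold lower number from compound 1 to compound 4 (1.09 log units; beyond the scatter). A sulfanyl substituent alone is therefore not enough, as compound 2 and compound 3 remain at a limit, like compound 1: the limit of > 50000 nM in this assay, at which 3 of the 4 values shown sit.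

The compounds shown leave open whether a plain benzyl group, without the methoxy, would give the same drop. They also leave open how a hydroxyl or a chlorine in place of that methoxy would read.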